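Trading 4-nitrobenzyl for octyl on a shared core

A few compounds are considered here, and "the series" means these few. Any claim that something is new, unique, unknown or untested is made for them only; others in the source may bear on it.

Of the compounds shown here, three built on one core have been tested in a functional assay on A549 cells (Homo sapiens) for antiproliferative activity, read by MTT assay; on this read-out higher numbers stand for weaker inhibition and lower numbers for stronger inhibition. Compound 1 (`CCc1ccccc1-n1cc(COc2ccc(/C=C/C(=O)c3ccc4c(c3O)CCC(C)(C)O4)cc2)nn1`) gives 112000 nM as its value. Compound 2 (`Cc1ccc(-n2cc(COc3ccc(/C=C/C(=O)c4ccc5c(c4O)CCC(C)(C)O5)cc3)nn2)cc1Br`) is reported as "not active" (no number reported) and has no number. For the measured compounds named here, compound 3 (`CC1(C)CCc2c(ccc(C(=O)/C=C/c3ccc(OCc4cn(Cc5ccc([N+](=O)[O-])cc5)nn4)cc3)c2O)O1`) gives 69900 nM as its value, so it holds one of only two numbers, and those two lie within the scatter of each other.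

Compound 4 (`CCCCCCCCn1cc(COc2ccc(/C=C/C(=O)c3ccc4c(c3O)CCC(C)(C)O4)cc2)nn1`) has not been measured. It differs from compound 3 as follows: heptyl in place of 4-nitrophenyl on a saturated chain carbon bound to an aromatic nitrogen that is, heptyl in place of 4-nitrophenyl on a saturated chain carbon bound to an aromatic nitrogen, or, cut one bond further out, 4-nitrobenzyl to octyl.

Going by the values given here, only one measured step touches this place, namely a 1.6-fold lower number from compound 1 to compound 3 (0.20 log units; within the scatter) and it put 4-nitrobenzyl in place of 2-ethylphenyl. Among the compounds with values here, no measured compound carries an open chain here, so this step is a weak guide. Since compound 2 gave no number, the same outcome remains possible for the new compound. The estimated step is a 1.1-fold higher number from compound 3 to compound 4 (0.06 log units; within the scatter) and so no shift beyond the scatter is expected. The expected value for compound 4 is 80000 nM (estimated range 25000 nM to 200000 nM).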

Compound 4, half-maximal inhibitory concentration: "not active" (no number reported)
Compound 4 has no reported number here, so the estimate cannot be set against anything.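

For the compounds shown here, compound 4 is reported as "not active" in this assay and carries no number, so no step from compound 3 to compound 4 can be read. Nothing else shown bears on this result. The compounds shown leave open what separates compound 2 and compound 4, both without numbers, from compound 1 and compound 3.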